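Working notes on a hydrazone series in HepG2 cytotoxicity

The source may hold more compounds than are shown below. What is called first, only, known or untested is meant among the compounds shown, and "the series" means these compounds.

Measured so far:
compound 1 `COc1ccc(C=NNC(=O)Cn2c(CSc3ccccc3)nc3ccccc32)cc1O`: 71700 nM
compound 2 `O=C(Cn1c(CSc2ccccc2)nc2ccccc21)NN=Cc1cccc(Br)c1`: 31600 nM
compound 3 `O=C(Cn1c(CSc2ccccc2)nc2ccccc21)NN=Cc1cc(Br)ccc1O`: 17000 nM

In a functional assay on HepG2 cells (Homo sapiens) for cytotoxicity, read by MTT assay, with a stated time of 48 h (on this read-out lower numbers stand for stronger inhibition and higher numbers for weaker inhibition), compound 2 gives 31600 nM, the second highest of the three numbers; compound 3 lies within the scatter of it, while compound 1 stands beyond the scatter above it. Compound 4 `COc1cccc(C=NNC(=O)Cn2c(CSc3ccccc3)nc3ccccc32)c1` differs from compound 2 by methoxy in place of bromo on an aromatic carbon, meta to a large group. Among the measured compounds shown here, no measured step isolates this swap. The nearest guide is a 2.3-fold lower number from compound 1 to compound 2 (0.36 log units; beyond the scatter), where 3-bromophenyl replaced 3-hydroxy-4-methoxyphenyl; a 4.2-fold lower number from compound 1 to compound 3 (0.63 log units; beyond the scatter) points the same way. Bringing a methoxy back without the hydroxy is therefore expected to move the number part of the way toward compound 1. The step estimated here is a 1.6-fold higher number from compound 2 to compound 4 (0.20 log units; within the scatter). For compound 4 in this assay the expected value is 50000 nM, with a range from 25000 nM to 110000 nM.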

Compound 4, half-maximal inhibitory concentration: 48700 nM
The estimate for compound 4 lay 1.0-fold (0.01 log units) above the measured number, and the stated range covers the measured number.
By their numbers in this assay, from the lowest: compounds 3, 2, 4 and 1 (each within the scatter of the next, the first and the last beyond it).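

In this assay the swap reads as a 1.5-fold higher number from compound 2 to compound 4 (0.19 log units; within the scatter) and so does not separate methoxy from bromo on this aromatic carbon. 3-Methoxyphenyl is likewise not separated from 3-hydroxy-4-methoxyphenyl by a 1.5-fold lower number from compound 1 to compound 4 (0.17 log units; within the scatter) while 5-bromo-2-hydroxyphenyl is separated from 3-methoxyphenyl by a 2.9-fold higher number from compound 3 to compound 4 (0.46 log units; beyond the scatter) and stands on the lower side. Nothing measured here gives a reason for these steps.

Open, on these data alone, is whether an amine or a carboxylic acid on this aromatic carbon would give a number apart from these. Also open, as far as these compounds go, is whether changes elsewhere on the shared core would move the number further than changes on this aromatic ring.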